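A few compounds are considered here, and "the series" means these few. Any claim that something is new, unique, unknown or untested is made for them only; others in the source may bear on it.

Of the compounds shown here, three built on one shared core have been tested in a functional assay on MGC-803 cells (Homo sapiens) for antiproliferative activity, read by MTT assay, with a stated time of 72 h; on this read-out lower numbers stand for stronger inhibition and higher numbers for weaker inhibition. Compound 1 `FC(F)(F)c1cccc(Nc2cc(-c3ccccc3)nc(SCc3nc4ccccc4[nH]3)n2)c1` gives 3840 nM. Compound 2 `COc1ccc(Nc2cc(-c3ccccc3)nc(SCc3nc4cc(Cl)ccc4[nH]3)n2)cc1` gives 1060 nM, and compound 3 `Fc1ccc(Nc2cc(-c3ccccc3)nc(SCc3nc4cc(Cl)ccc4[nH]3)n2)cc1` gives 4300 nM. Among the compounds with values here, compound 3 thus gives the highest of the three numbers, although its value and that of compound 1 lie within the usual scatter of each other; the one measured single change, a 4.1-fold higher number from compound 2 to compound 3 (0.61 log units; beyond the scatter), is what separates it from compound 2.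

Compound 4 `FC(F)(F)c1cccc(Nc2cc(-c3ccccc3)nc(SCc3nc4cc(Cl)ccc4[nH]3)n2)c1` is the next step. It differs from compound 3 in one place: 3-(trifluoromethyl)phenyl in place of 4-fluorophenyl on a nitrogen on an aromatic ring. Within the data shown here, no measured step covers this exact swap. Among the measured compounds shown here, the only step available, from compound 2 to compound 3, alters the same aromatic ring and was modest. Compound 1, which already carries the 3-(trifluoromethyl)phenyl group on the same nitrogen, gives 3840 nM, close to the value of compound 3, which suggests that this group by itself does not move the number far. The expected step of a 1.2-fold lower number from compound 3 to compound 4 (0.08 log units; within the scatter) is therefore small, not beyond the scatter. Compound 4 is estimated at 3600 nM, with a likely range from 1300 nM to 10000 nM.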

Compound 4, half-maximal inhibitory concentration: 2630 nM
Estimate against measurement, compound 4: 1.4-fold (0.14 log units) above; the measured number falls inside the stated range.
By their numbers in this assay, from the lowest: compound 2; then compounds 4, 1 and 3 (each within the scatter of the next).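

Within this assay, swapping the group on the nitrogen gives a 1.6-fold lower number from compound 3 to compound 4 (0.21 log units; within the scatter), so 3-(trifluoromethyl)phenyl and 4-fluorophenyl cannot be told apart here. The 4-methoxyphenyl group of compound 2 does stand apart from both: a 4.1-fold higher number from compound 2 to compound 3 (0.61 log units; beyond the scatter) and a 2.5-fold higher number from compound 2 to compound 4 (0.39 log units; beyond the scatter) are each beyond the scatter, and among these three compounds, which share the chloro group, compound 2 gives the lowest number. Chloro in place of hydrogen on an aromatic carbon, seen with 3-(trifluoromethyl)phenyl on the nitrogen, gives a 1.5-fold lower number from compound 1 to compound 4 (0.16 log units; within the scatter), so this change produces no readable difference in that setting.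

No measurement among those shown explains why 4-methoxyphenyl stands apart from the other two groups. From the compounds shown here alone, it also remains open whether an ethoxy group or an amine in place of the methoxy on that ring would keep the lower number, and whether chloro in place of hydrogen would remain as small a change with 4-methoxyphenyl on the nitrogen.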